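The source may hold more compounds than are shown below. What is called first, only, known or untested is meant among the compounds shown, and "the series" means these compounds.

Compound 2 `COc1cc2cc(C#N)ccc2c(OC)c1Oc1cc(NC2CC2)nc(Nc2ccc(C#N)cc2)n1` is one of three measured analogues sharing a core that differ only in the amino substituent. In an ADME assay on MT4 cells (Homo sapiens) for cytotoxicity, read by MTT assay, with a stated time of 5 days (a lower number here means that less compound is tolerated, a higher number that more compound is tolerated), compound 2 gives > 125000 nM, a limit of the assay rather than a number. Compound 1 `CCNc1cc(Oc2c(OC)cc3cc(C#N)ccc3c2OC)nc(Nc2ccc(C#N)cc2)n1` gives > 125000 nM, also a limit. Compound 3 `COc1cc2cc(C#N)ccc2c(OC)c1Oc1cc(NCC(O)CO)nc(Nc2ccc(C#N)cc2)n1` gives 29500 nM. The step that the two limits leave unreadable from compound 1 to compound 2 cannot be read because of the limit of > 125000 nM in this assay, at which 2 of the 3 values shown sit, whereas an at least 4.2-fold lower number from compound 1 to compound 3 (0.62 log units; beyond the scatter) and an at least 4.2-fold lower number from compound 2 to compound 3 (0.62 log units; beyond the scatter). Compound 4 `COc1cc2cc(C#N)ccc2c(OC)c1Oc1cc(N2CCC(O)C2)nc(Nc2ccc(C#N)cc2)n1` differs from compound 2 by 3-hydroxypyrrolidin-1-yl in place of cyclopropylamino on an aromatic carbon. Going by the values given here, since compound 3, the only analogue carrying hydroxyl groups, showed an at least 4.2-fold lower number from compound 2 to compound 3 (0.62 log units; beyond the scatter), a lower number is expected for compound 4, though a limit remains possible; the estimated step is an at least 1.5-fold lower number from compound 2 to compound 4 (0.19 log units; that floor lies within the scatter). Compound 4 is therefore expected to give about 80000 nM, between 25000 nM and 125000 nM.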

Compound 4, half-maximal cytotoxic concentration: > 125000 nM
Compound 4 was reported as a limit; the forecaster's own chance of this, stated with the estimate: 45%; at least 1.5-fold (0.19 log units) between middle value and limit.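

At this position, a hydroxyl group on the incoming substituent no longer goes with a lower number in this assay: 3-hydroxypyrrolidin-1-yl differs from (2,3-dihydroxypropyl)amino by an at least 4.2-fold higher number from compound 3 to compound 4 (0.62 log units; beyond the scatter). Among the compounds shown, only compound 3 now stands apart from the others. The steps from compound 1 and compound 2 to compound 4 cannot be read because both ends are limits: the limit of > 125000 nM in this assay, at which 3 of the 4 values shown sit.

From the compounds shown here alone, it remains open whether a single hydroxyl on an open chain, as in 2-hydroxyethylamino, would behave like compound 3 or compound 4. How a piperazine or a carboxylic acid would read here is also unsettled.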